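The compounds below may be only part of what the source reports. "The series", "measured", "known", "first", "only" and "open" are said of these compounds alone.

Measured so far in a functional assay on cells (Cancer cell lines, Homo sapiens) for inhibition; on this read-out lower numbers stand for stronger inhibition of growth and higher numbers for weaker inhibition of growth:
compound 1 `Cc1cc(-c2nc3sc(C)cn3c2/C=N/NC(=N)N)c(C)s1`: 32400 nM
compound 2 `Cc1cn2c(/C=N/NC(=N)N)c(-c3ccsc3)nc2s1`: 28200 nM
compound 3 `N=C(N)N/N=C/c1c(-c2ccsc2)nc2sccn12`: 29500 nM

Compound 3 sits level with the other two, within the scatter of both, so no order can be read among them. Compound 4 `N=C(N)N/N=C/c1c(-c2cccs2)nc2sccn12` has the same atoms joined differently, with thiophen-2-yl in place of thiophen-3-yl on an aromatic carbon. Among the measured compounds shown here, two measured steps bear on this. The closer one, a 1.1-fold lower number from compound 1 to compound 2 (0.06 log units; within the scatter), altered this same group, while a 1.0-fold higher number from compound 2 to compound 3 (0.02 log units; within the scatter) altered the core. For the measured compounds named here, no measured step tests this particular swap, but neither step moved this assay beyond the scatter, so none is expected here. The estimated step is a 1.1-fold lower number from compound 3 to compound 4 (0.02 log units; within the scatter). For compound 4 the expected value is 28000 nM, with an estimated range of 14000 nM to 55000 nM.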

Compound 4, concentration for total growth inhibition: 21900 nM
Estimate against measurement, compound 4: 1.3-fold (0.11 log units) above; measured number inside the range.
By their numbers in this assay, from the lowest: compounds 4, 2, 3 and 1 (each within the scatter of the next).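

The earlier steps shown here on this group and on the core removed methyl groups, whereas this one keeps the same atoms and only rejoins them, with thiophen-2-yl in place of thiophen-3-yl. That change gives a 1.3-fold lower number from compound 3 to compound 4 (0.13 log units; within the scatter) in this assay, so at this position the point of attachment of the thiophene makes no difference that can be told from scatter. Nothing available here bears on this result.

From the compounds shown here alone, all four compounds carry a thiophene at this position, so whether a phenyl ring or an amine there would shift growth inhibition remains open.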